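The source may hold more compounds than are shown below. What is called first, only, known or untested is meant among the compounds shown, and "the series" means these compounds.

Compound 2 `C/C1=C\CC(C)(C)/C=C/C(=O)N(Cc2cn(CCOc3ccc(C(=O)/C=C/c4ccc(C)cc4)c(O)c3)nn2)/C(C)=C/CC1` gives 0.91 ug/mL in a functional assay on Lu cells (Homo sapiens) for antiproliferative activity; a lower number here means a stronger inhibitor, a higher number a weaker inhibitor; compound 1 `COc1cccc(/C=C/C(=O)c2ccc(OCCn3cc(CN4C(=O)/C=C/C(C)(C)C/C=C(\C)CC/C=C/4C)nn3)cc2O)c1` gives 0.61 ug/mL in this assay, and the two numbers lie within the scatter of each other, as the step of a 1.5-fold higher number from compound 1 to compound 2 (0.17 log units; within the scatter) shows. Compound 3 `C/C1=C\CC(C)(C)/C=C/C(=O)N(Cc2cn(CCOc3ccc(C(=O)/C=C/c4ccc(C(C)C)cc4)c(O)c3)nn2)/C(C)=C/CC1` differs from compound 2 by isopropyl in place of methyl on an aromatic carbon. Among the compounds with values here, no measured step enlarges a group on that aromatic ring; the only known step, a 1.5-fold higher number from compound 1 to compound 2 (0.17 log units; within the scatter), exchanged whole aryl groups and stayed within the scatter. For compound 3 the expected step is therefore small, a 1.0-fold lower number from compound 2 to compound 3 (0.00 log units; within the scatter). Compound 3 is estimated at 0.9 ug/mL, with a range of 0.4 ug/mL to 2 ug/mL.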

Compound 3, half-maximal inhibitory concentration: 0.77 ug/mL
Compound 3: middle estimate off by 1.2-fold (0.07 log units), on the high side; measured number inside the range.
By their numbers in this assay, from the lowest: compounds 1, 3 and 2 (each within the scatter of the next).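

In this assay, the aromatic carbon para to a large group takes isopropyl in place of methyl with a 1.2-fold lower number from compound 2 to compound 3 (0.07 log units; within the scatter), so this change in size at this position stays within the scatter. Exchanging 3-methoxyphenyl for 4-isopropylphenyl likewise gives a 1.3-fold higher number from compound 1 to compound 3 (0.10 log units; within the scatter). No supporting data bear on this result. Open, from the compounds shown here alone, is whether an amine or a carboxylic acid on this aromatic carbon would move the number beyond the scatter, and whether a longer chain there would do so.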